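Para Trifluoromethyl in Place of Methyl on the Shared Core

The source may report more compounds than this note shows. Statements on the series, on what has been measured and on what is new or still open speak of the compounds shown alone.

Compound 3 `Cc1ccc(Nc2nc3nonc3nc2Nc2ccccc2F)cc1` stands second highest of the three numbers in an assay on mitochondria from L6 cells (Rattus norvegicus) for activation, with a stated time of 90 min (a higher number here means that more compound is needed for the effect, a lower number that less compound is needed), giving 2100 nM. Compound 1 `Fc1ccccc1Nc1nc2nonc2nc1NC1CCCCC1` gives 13400 nM and compound 2 `Fc1cccc(Nc2nc3nonc3nc2Nc2ccccc2F)c1` gives 190 nM; the step of an 11-fold higher number from compound 2 to compound 3 (1.04 log units; beyond the scatter) shows how much the aryl substituent matters. Compound 4 `Fc1ccccc1Nc1nc2nonc2nc1Nc1ccc(C(F)(F)F)cc1` differs from compound 3 by trifluoromethyl in place of methyl on an aromatic carbon. Among the compounds with values here, no measured step swaps one para group for another, so the steps of a 6.4-fold lower number from compound 1 to compound 3 (0.80 log units; beyond the scatter) and an 11-fold higher number from compound 2 to compound 3 (1.04 log units; beyond the scatter) bear only loosely on it. Compound 4 is therefore expected to give a step of a 1.1-fold lower number from compound 3 to compound 4 (0.02 log units; within the scatter), of uncertain direction. Compound 4 is estimated at 2000 nM, with a range from 500 nM to 8000 nM.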

Compound 4, half-maximal effective concentration: 270 nM
Compound 4: middle estimate off by 7.4-fold (0.87 log units), on the high side, outside the stated range (below it).
By their numbers in this assay, from the lowest: compounds 2 and 4 (each within the scatter of the next); then compound 3; then compound 1.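

With the rest of the structure held fixed, trifluoromethyl in place of methyl gives a 7.8-fold lower number from compound 3 to compound 4 (0.89 log units; beyond the scatter) in this assay and so shows that the group on this aromatic carbon alone can move the number beyond the scatter. Compound 4 also stands within the scatter of compound 2, so two different aryl groups reach that level. Nothing measured here explains the step.

The compounds shown leave open how a methoxy group, a nitrile or an amine at this place would compare with methyl and trifluoromethyl.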